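This account rests on a few compounds, and the source may have more. Where it says the series, first, only, none or still open, it means among the compounds named here.

Compound 1 `ClCc1cccc(Cn2cnc3ncnc(Cl)c32)c1` is one of two measured compounds of this series, the other being compound 2 `ClCc1ccc(Cn2cnc3nc(Cl)nc(Cl)c32)cc1`. In a functional assay on MOLT-4 cells (Homo sapiens) for cytotoxicity, read by sulforhodamine B assay, with a stated time of 48 h (on this read-out higher numbers stand for weaker inhibition of growth and lower numbers for stronger inhibition of growth), compound 1 gives 29500 nM, the higher of the two numbers recorded so far. In this assay compound 2 gives 5490 nM. Going by the values given here, the two compounds differ in more than one place, so no single step connects them; their two values simply show compound 2 with the lower number, a gap that lies beyond the usual scatter.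

Compound 3 `ClCc1cccc(Cn2cnc3nc(Cl)nc(Cl)c32)c1` has not yet been measured in this assay. It differs from compound 1 in a single place: chloro in place of hydrogen on an aromatic carbon. Within the shared core, this is a chloro entering on an aromatic carbon of a six-membered aromatic ring with two nitrogens, between two ring nitrogen atoms, meta to a chloro group and meta and para to a fused ring.

Among the compounds with values here, no measured pair shows this exact step. Given that compound 2, which also carries two chloro groups on its core, gives 5490 nM, the step from compound 1 to compound 3 is expected to lower the number by a 3.7-fold lower number from compound 1 to compound 3 (0.57 log units; beyond the scatter). Compound 3 is therefore estimated at 8000 nM, with a range from 2500 nM to 25000 nM.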

Compound 3, concentration for total growth inhibition: 2290 nM
Compound 3: the middle estimate sits 3.5-fold (0.54 log units) above what was measured; the measured number lies below the stated range.
By their numbers in this assay, from the lowest: compound 3; then compound 2; then compound 1.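

In this assay the entry of chloro in place of hydrogen on an aromatic carbon, between two ring nitrogen atoms and meta to a chloro group, brings a 13-fold lower number from compound 1 to compound 3 (1.11 log units; beyond the scatter) in one single change, a large step beyond the usual scatter. Going by these compounds alone, this gives the first direct reading of this position, which compound 1 and compound 2 could not give, since those two differ in more than one place and their gap cannot be assigned to any one of them. Nothing at hand accounts for the size of this step, so it stands as an observation on this position alone.

The compounds shown hold only hydrogen or chloro at this position, so it remains open how an amine, a methoxy group or a thiol placed there would read in this assay. Whether the step keeps its size in the setting of compound 2 also stays open, as no counterpart of compound 2 with hydrogen at this position is among the compounds shown.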